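A Larger Side Chain on the Glycine Ester

The source may hold more compounds than are shown below. What is called first, only, known or untested is meant among the compounds shown, and "the series" means these compounds.

Measured compounds:
compound 1, `O=C(O)[C@@H]1CCCN1C(=O)CN(c1nc(Cl)nc2[nH]cnc12)C1CC1` — 23.6%
compound 2, `O=C(CN(c1nc(Cl)nc2[nH]cnc12)C1CC1)NCC(=O)OCc1ccccc1` — 21.7%
compound 3, `O=C(CN(c1ncnc2c1ncn2C1CCCCO1)C1CC1)NCC(=O)OCc1ccccc1` — 17.2%

All three values come from a functional assay on the whole organism (Tail, strain ICR) with Mus musculus as the target, in the tail flick test, with a stated time of 120 min, at a dose of 25 umol/kg by the oral route; a higher number here means a stronger effect of the compound at the dose given, a lower number a weaker effect. Compound 2 sits second highest of the three, yet its value lies within the scatter of both compound 1 and compound 3, so none of the three can be told apart from the others. Compound 4, `N=C(N)NCCC[C@H](NC(=O)CN(c1nc(Cl)nc2[nH]cnc12)C1CC1)C(=O)OCc1ccccc1`, has not been measured. It differs from compound 2 by a group of 7 heavy atoms (4 carbon, 3 nitrogen; no ring) in place of a hydrogen atom, on a saturated chain carbon bound to an amide-type nitrogen and a carbonyl carbon. Within the data shown here, no step between measured compounds is available to show how much a change of this kind moves the read-out. Among the measured compounds shown here, the three measured values do not separate from one another, and that is the only guide at hand. The step of a number 0.3 percentage points higher from compound 2 to compound 4 (within the scatter) is therefore expected to be none beyond the scatter. Compound 4 is estimated at 22%, with a range from 10% to 34%.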

Compound 4, a percentage reported as activity, at one dose (the size of the read-out at that dose, not a potency): 10.2%
Estimate against measurement, compound 4: 11.8 percentage points above; low and high end bracket the measured number.
By their numbers in this assay, from the lowest: compounds 4, 3, 2 and 1 (each within the scatter of the next, the first and the last beyond it).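

In this assay, a group of 7 heavy atoms (4 carbon, 3 nitrogen; no ring) in place of a hydrogen atom, on a saturated chain carbon bound to an amide-type nitrogen and a carbonyl carbon, gives a number 11.5 percentage points lower from compound 2 to compound 4 (beyond the scatter). So a substituent on this carbon can lower the read-out at this dose, which the earlier compounds, all within the scatter of one another, could not show. Nothing at hand explains the drop.

From the compounds shown here alone, whether a methyl group on the same carbon, or a shorter chain ending in an amine, would keep the read-out of compound 2 remains open.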